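Lengthening the Amino Side Chain of Compound 3

The source may hold more compounds than are shown below. What is called first, only, known or untested is meant among the compounds shown, and "the series" means these compounds.

Three measured compounds share one scaffold and differ only in the amine-bearing chain. Compound 1 `CN[C@@H](CC(C)C)CN(C(=O)[C@@H]1C[C@H]1c1ccccc1)c1ccc(-c2ccccc2)cc1` gives 2 nM in a functional assay for agonist activity at G protein-coupled receptor 88 (Homo sapiens), read by HTRF and cAMP accumulation; on this read-out lower numbers stand for an effect already at smaller amounts and higher numbers for an effect only at larger amounts of compound. Compound 2 `N[C@@H](CC1CCCCC1)CN(C(=O)[C@@H]1C[C@H]1c1ccccc1)c1ccc(-c2ccccc2)cc1` gives 1.7 nM in this assay, and compound 3 `CC(C)[C@H](N)CN(C(=O)[C@@H]1C[C@H]1c1ccccc1)c1ccc(-c2ccccc2)cc1` gives 1.1 nM. Compound 3 shows the lowest of the three numbers, but its distance to both neighbours is within the scatter: a 1.8-fold lower number from compound 1 to compound 3 (0.26 log units; within the scatter) and a 1.5-fold lower number from compound 2 to compound 3 (0.19 log units; within the scatter). The step of a 1.2-fold lower number from compound 1 to compound 2 (0.07 log units; within the scatter) is likewise within the scatter, so across these three the branch on the chain carbon bearing the amine made no difference beyond noise.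

Compound 4 `CCC(CC)C(N)CCN(C(=O)[C@@H]1C[C@H]1c1ccccc1)c1ccc(-c2ccccc2)cc1` carries 2-amino-3-ethylpentyl in place of 1-amino-2-methylpropyl on a saturated chain carbon bound to an amide-type nitrogen. Going by the values given here, the measured steps speak to the size of the branch, where isopropyl, cyclohexylmethyl and the methylaminated isobutyl chain all landed together; no measured pair tests the extra chain carbon between the amide-type nitrogen and the amine, nor the loss of the defined stereocentre. An account built on these steps therefore expects little change, with the untested chain extension widening the uncertainty toward weaker activity. For compound 4 the expected step is a 3.6-fold higher number from compound 3 to compound 4 (0.56 log units; beyond the scatter), giving an estimate of 4 nM with a range from 1 nM to 30 nM.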

Compound 4, half-maximal effective concentration: 2 nM
Estimate against measurement, compound 4: 2.0-fold (0.30 log units) above; the measured number falls inside the stated range.
By their numbers in this assay, from the lowest: compounds 3, 2, 1 and 4 (each within the scatter of the next).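

Replacing 1-amino-2-methylpropyl with 2-amino-3-ethylpentyl gives a 1.8-fold higher number from compound 3 to compound 4 (0.26 log units; within the scatter) in this assay. The comparisons with the other chains read the same way, with a 1.2-fold higher number from compound 2 to compound 4 (0.07 log units; within the scatter) and no change at the digits printed from compound 1 to compound 4 (within the scatter). This position, on a saturated chain carbon bound to an amide-type nitrogen, therefore accepts a group of 8 heavy atoms in place of 5, with the amine carried further out and no defined stereocentre, without any shift beyond the scatter.

The longer chain, the larger branch and the loss of the defined stereocentre all arrive together in compound 4, and the compounds shown do not separate them, nor do they show how a single pure stereoisomer of this chain or a carboxylic acid in place of the amine would read. No supporting evidence is available to explain why these chains read alike.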